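This account rests on a few compounds, and the source may have more. Where it says the series, first, only, none or still open, it means among the compounds named here.

Measured so far in a physicochemical assay for solubility, read by LC-MS, in phosphate buffer, measured as thermodynamic solubility, with a stated time of 24 h, at pH 7.4; a higher number here means a more soluble compound, a lower number a less soluble compound:
compound 1 `COc1ccc(-c2c[nH]c3ncc(-c4cnn(C)c4)cc23)cc1`: 5000 nM
compound 2 `Cn1cc(-c2cnc3[nH]cc(-c4ccc(C(N)=O)cc4)c3c2)cn1`: 3000 nM

Compound 2 stands at the lowest of the two numbers shown, with compound 1 nearest; the gap between them is a 1.7-fold lower number from compound 1 to compound 2 (0.22 log units; within the scatter) and lies within the scatter. Compound 3 `Cn1cc(-c2cnc3[nH]cc(-c4ccc(O)cc4)c3c2)cn1` differs from compound 2 by hydroxy in place of carbamoyl on an aromatic carbon. Among the compounds with values here, the only measured step that bears on this change is that one, and it moved nothing beyond the scatter, so no step beyond the scatter is expected in this assay in either direction. Compound 3 is therefore estimated at 4000 nM (range 1500 nM to 12000 nM). The expected step is a 1.3-fold higher number from compound 2 to compound 3 (0.12 log units; within the scatter).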

Compound 3, solubility: < 3000 nM
Compound 3: a limit, no number; the forecaster's own chance of this, stated with the estimate: 5%; at least 1.3-fold (0.12 log units) between middle value and limit.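

In this assay compound 3 gives < 3000 nM, which is a limit and not a number. Hydroxy in place of carbamoyl gives a number no higher from compound 2 to compound 3 (the limit leaves the size open) and the size of this step cannot be read. Hydrogen in place of methyl on the oxygen gives an at least 1.6-fold lower number from compound 1 to compound 3 (0.22 log units; that floor lies within the scatter), a floor within the scatter, so hydroxy and methoxy are not yet separated. This place, para to a large group, now carries the only limit in the set: the limit of < 3000 nM in this assay, at which 1 of the 3 values shown sits.

On these data alone, the true size of the step to compound 3 stays open. Also open, as far as these compounds go, is what an amine or a carboxylic acid would give at this place.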